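Dimethylamino for acetyl on the pendant phenyl

A few compounds are considered here, and "the series" means these few. Any claim that something is new, unique, unknown or untested is made for them only; others in the source may bear on it.

Within the data shown here, compound 1 `COc1cc(C)cc(-c2c(-c3ccnc(-c4ccc(C(C)=O)cc4)c3)cnn2CC#N)c1` gives 2860 nM in a functional assay on OVCAR-8 cells (Homo sapiens) for inhibition, read by sulforhodamine B assay, with a stated time of 48 h (on this read-out higher numbers stand for weaker inhibition of growth and lower numbers for stronger inhibition of growth), the highest of the two numbers so far. Compound 2 `COc1cc(C)cc(-c2nn(CC#N)cc2-c2ccnc(-c3ccc(N(C)C)cc3)c2)c1`, which carries the dimethylamino group on a differently placed core, gives 522 nM in this assay. Compound 3 `COc1cc(C)cc(-c2c(-c3ccnc(-c4ccc(N(C)C)cc4)c3)cnn2CC#N)c1` is compound 1 with the exchange dimethylamino in place of acetyl on an aromatic carbon on the aromatic carbon para to a large group. Among the measured compounds shown here, with no directly comparable step available, the expectation for compound 3 rests on compound 2 at 522 nM: a step of a 4.1-fold lower number from compound 1 to compound 3 (0.61 log units; beyond the scatter) toward stronger inhibition, beyond the scatter, is expected. Compound 3 is estimated at 700 nM, within 250 nM to 2000 nM.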

Compound 3, concentration for 50% growth inhibition: 236 nM
Compound 3: middle estimate off by 3.0-fold (0.47 log units), on the high side, outside the stated range (below it).
By their numbers in this assay, from the lowest: compound 3; then compound 2; then compound 1.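

On the shared core, the change from 4-acetylphenyl to 4-(dimethylamino)phenyl gives a 12-fold lower number from compound 1 to compound 3 (1.08 log units; beyond the scatter) in this assay and moves toward stronger inhibition of growth. Among these compounds, this is the first reading of this position from a pair differing in one place, and the large step shows that the result is sensitive to the group held there. Nothing measured here bears on the origin of the step.

Going by these compounds, whether a primary amine, a morpholine or a carboxylic acid at this position would keep or lose the gain remains open. Also open, on these data alone, is whether an acetyl group on the differently placed core of compound 2 would give a step of similar size.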